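Replacing Naphthyl with Chlorophenyl in an EP4 Binding Series

The source may report more compounds than this note shows. Statements on the series, on what has been measured and on what is new or still open speak of the compounds shown alone.

Compound 1, `O=C(O)c1ccc(CCCN2C(=O)CC[C@@H]2CCC(O)Cc2ccccc2)s1`: 21 nM
Compound 2, `O=C(O)c1ccc(CCCN2C(=O)CC[C@@H]2CCC(O)Cc2ccc3ccccc3c2)s1`: 65 nM

Of the compounds shown here, two have been measured in an assay on HEK293 cells for binding affinity to prostaglandin E2 receptor EP4 subtype (Rattus norvegicus); on this read-out lower numbers stand for stronger inhibition and higher numbers for weaker inhibition. Compound 1 `O=C(O)c1ccc(CCCN2C(=O)CC[C@@H]2CCC(O)Cc2ccccc2)s1` gives 21 nM in this assay, and compound 2 `O=C(O)c1ccc(CCCN2C(=O)CC[C@@H]2CCC(O)Cc2ccc3ccccc3c2)s1` gives 65 nM. Among the compounds with values here, compound 2 therefore holds the higher of the two numbers, and the only measured step, a 3.1-fold higher number from compound 1 to compound 2 (0.49 log units; beyond the scatter), separates it from compound 1.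

Compound 3 `O=C(O)c1ccc(CCCN2C(=O)CC[C@@H]2CCC(O)Cc2ccc(Cl)cc2)s1` is not yet measured. It differs from compound 2 by 4-chlorophenyl in place of naphthalen-2-yl on a saturated chain carbon, two bonds along the chain from an oxygen on a saturated carbon. Within the data shown here, the only step that bears on this change is the one from compound 1 to compound 2, where naphthalen-2-yl in place of phenyl gave the higher number. Since 4-chlorophenyl carries a single six-membered aromatic ring, as the phenyl of compound 1 does, a step back toward the number of compound 1 is expected, roughly a 2.6-fold lower number from compound 2 to compound 3 (0.41 log units; beyond the scatter). Compound 3 is accordingly estimated at 25 nM, with a range from 8 nM to 80 nM.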

Compound 3, half-maximal inhibitory concentration: 80 nM
Compound 3: the middle estimate sits 3.2-fold (0.51 log units) below what was measured, within the range that was stated.
By their numbers in this assay, from the lowest: compound 1; then compounds 2 and 3 (each within the scatter of the next).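

In this assay, a 1.2-fold higher number from compound 2 to compound 3 (0.09 log units; within the scatter) keeps the two compounds within the scatter of each other, so going from the two aromatic rings of naphthalen-2-yl to the one of 4-chlorophenyl does not return the number to that of compound 1. The other new step, a 3.8-fold higher number from compound 1 to compound 3 (0.58 log units; beyond the scatter), shows that a single chloro in place of hydrogen on an aromatic carbon is enough to raise the number, so among these three compounds the count of aromatic rings alone does not set it. No measurement available here explains why these two larger groups give such similar numbers.

Going by these compounds, it remains open whether fluoro or methoxy in place of the chloro would also raise the number. On these data alone, the effect of a cyclohexyl in place of the phenyl also remains open.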